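Dropping the phenyl from compound 1

The compounds below may be only part of what the source reports. "The series", "measured", "known", "first", "only" and "open" are said of these compounds alone.

Three compounds carry numbers in a functional assay on Jurkat cells (Homo sapiens) for cytotoxicity, read by luminescence and CellTiter-Glo, with a stated time of 3 days; on this read-out higher numbers stand for weaker inhibition and lower numbers for stronger inhibition. Compound 1 `O=C(Nc1cc(C(F)(F)F)cc(C(F)(F)F)c1)c1cc(Br)c(-c2ccccc2)cc1O` gives 680 nM, compound 2 `O=C(Nc1ccc(C(F)(F)F)cc1)c1ccc(Cl)cc1O` gives 670 nM and compound 3 `O=C(Nc1ccc(C(F)(F)F)cc1)c1cc(Br)c(-c2ccccc2)cc1O` gives 740 nM. Compound 1 therefore stands within the scatter of both others, and the three values cannot be ranked.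

Compound 4 `O=C(Nc1cc(C(F)(F)F)cc(C(F)(F)F)c1)c1cc(Br)ccc1O` is still unmeasured. It departs from compound 1 by hydrogen in place of phenyl on an aromatic carbon, ortho to a bromo group, meta to a hydroxy group and para to a large group.

Going by the values given here, no measured pair isolates this change, so the expectation rests on indirect evidence. Compound 2, without a phenyl group, gives 670 nM, while compound 3, with one, gives 740 nM. These two also differ elsewhere, so the comparison is only a loose guide. No step beyond the scatter is expected in this assay, and no direction is favoured. The expected size is a 1.1-fold lower number from compound 1 to compound 4 (0.04 log units; within the scatter). For compound 4 the estimated value is 620 nM, with an expected range of 250 nM to 1500 nM.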

Compound 4, half-maximal inhibitory concentration: 350 nM
Compound 4: middle estimate off by 1.8-fold (0.25 log units), on the high side; low and high end bracket the measured number.
By their numbers in this assay, from the lowest: compounds 4, 2, 1 and 3 (each within the scatter of the next, the first and the last beyond it).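

In this assay, going by these compounds alone, the phenyl on this aromatic carbon, ortho to a bromo group, meta to a hydroxy group and para to a large group, now has a direct reading for the first time. Hydrogen in place of phenyl gives a 1.9-fold lower number from compound 1 to compound 4 (0.29 log units; within the scatter), a step printed as within the scatter, so this pair shows no clear dependence of the read-out on the phenyl and the number stays in the same range without that ring. Nothing measured here accounts for the step or tells what the phenyl does at this position.

On these data alone, whether a methoxy group, an amine or a carboxylic acid on this carbon would read the same remains open. Also open, as far as these compounds go, is whether hydrogen in place of phenyl gives a similar step on the core of compound 3.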